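Aryl changes on the ring amine nitrogen

The compounds below may be only part of what the source reports. "The series", "measured", "known", "first", "only" and "open" are said of these compounds alone.

Compound 1 `Nc1scc(CN2CCN(c3ccccc3C(F)(F)F)CC2)c1C(=O)c1ccc(Cl)cc1`, compound 2 `Nc1scc(CN2CCN(c3ccc(OC(F)(F)F)cc3)CC2)c1C(=O)c1ccc(Cl)cc1` and compound 3 `Nc1scc(CN2CCN(c3c(F)cc(F)cc3F)CC2)c1C(=O)c1ccc(Cl)cc1` share one core and differ only in the group on the amine nitrogen in a ring. In a functional assay on CHO cells with adenosine receptor A1 (Homo sapiens) as the target, read by cAMP accumulation and immunoassay, with a stated time of 6 min, tested at 0.01 uM (on this read-out higher numbers stand for a weaker effect at the one concentration tested and lower numbers for a stronger effect), compound 1 gives 0%, compound 2 gives 0% and compound 3 gives 4.2%. On the numbers shown compound 3 stands highest, yet the step of a number 4.2 percentage points higher from compound 1 to compound 3 (within the scatter) and the step of a number 4.2 percentage points higher from compound 2 to compound 3 (within the scatter) both lie within the scatter, as does no change at the digits printed from compound 1 to compound 2 (within the scatter), so no order among the three can be claimed. None of the three groups tried so far moves the read-out.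

Compound 4 `Nc1scc(CN2CCN(c3ccc(Cl)c(Cl)c3)CC2)c1C(=O)c1ccc(Cl)cc1` continues the same exchange: 3,4-dichlorophenyl in place of 2,4,6-trifluorophenyl on an amine nitrogen in a ring. All three measured steps bear on it, since each also swaps the group on this nitrogen, and none left the scatter. A step of no size beyond the scatter is therefore expected, a number 2.2 percentage points lower from compound 3 to compound 4 (within the scatter). Compound 4 is estimated at 2% in this assay, within 0% to 12%.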

Compound 4, a percentage reported as activity, at one concentration (the size of the read-out at that concentration, not a potency): -1.2%
Compound 4: the middle estimate sits 3.2 percentage points above what was measured; the whole stated range lies above it.
By their numbers in this assay, from the lowest: compounds 4, 1, 2 and 3 (each within the scatter of the next).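

With 3,4-dichlorophenyl on the amine nitrogen in a ring, the steps are a number 5.4 percentage points lower from compound 3 to compound 4 (within the scatter) and a number 1.2 percentage points lower from compound 2 to compound 4 (within the scatter) and also a number 1.2 percentage points lower from compound 1 to compound 4 (within the scatter) in this assay at the one concentration tested. A chlorine-bearing aryl group therefore joins the fluorine-bearing ones at this position, and none of the four groups separates from the others on this read-out. No measurement at hand offers a reason for this lack of separation.

Going by these compounds, whether a group other than a substituted phenyl on this nitrogen, such as a benzyl, an acetyl or a simple alkyl chain, or a phenyl carrying an amine or a carboxylic acid, would move the read-out stays open. Also open, on these data alone, is whether the four compounds stay together at other concentrations, since a single concentration gives no potency.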